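The source may report more compounds than this note shows. Statements on the series, on what has been measured and on what is new or still open speak of the compounds shown alone.

Compound 3 `Cc1cc(C#N)cn2c(CSCCc3ccccc3)cnc12` carries a cyano group on its core, and in an ADME assay on HEL cells (Homo sapiens) for cytotoxicity, with a stated time of 3 days (a lower number here means that less compound is tolerated, a higher number that more compound is tolerated), compound 3 gives 20 ug/mL. Compound 2 `Cc1cc(N2CCCC2)cn2c(CSCCc3ccccc3)cnc12` gives in this assay 20 ug/mL, so the two stand level at the digits shown, and the step of no change at the digits printed from compound 2 to compound 3 (within the scatter) lies within the scatter. Compound 1 `Cc1cc(-c2ccc3[nH]ccc3c2)cn2c(CSCCc3ccccc3)cnc12` gives in this assay >= 20 ug/mL, which is a limit of the assay and not a number (the limit of >= 20 ug/mL in this assay, at which 1 of the 3 values shown sits). From that limit the steps of a number no higher from compound 1 to compound 2 (the limit leaves the size open) and a number no higher from compound 1 to compound 3 (the limit leaves the size open) can only be said to go no higher, their size staying open. Among the three, compound 3 therefore stands level with compound 2, with compound 1 at a limit.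

Compound 4 `Cc1cc(Sc2ccc(O)cc2)cn2c(CSCCc3ccccc3)cnc12` is the next member. Its difference from compound 3 is (4-hydroxyphenyl)sulfanyl in place of cyano on an aromatic carbon. The three measured steps all concern exchanges at this same aromatic carbon, and none of them shows a change beyond the scatter; the two from compound 1 have no readable size. For the measured compounds named here, no measured step points in a direction for compound 4, so the expectation for the step of no change at the digits printed from compound 3 to compound 4 (within the scatter) is no change beyond the scatter. Compound 4 is accordingly expected to give about 20 ug/mL in this assay, between 10 ug/mL and 40 ug/mL.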

Compound 4, minimum cytotoxic concentration: 4 ug/mL
The estimate for compound 4 lay 5.0-fold (0.70 log units) above the measured number, outside the stated range (below it).
By their numbers in this assay, from the lowest: compound 4; then compounds 2 and 3 (each within the scatter of the next).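

In this assay, for the compounds shown here, this aromatic carbon proves sensitive for the first time: the exchange for (4-hydroxyphenyl)sulfanyl brings a 5.0-fold lower number from compound 3 to compound 4 (0.70 log units; beyond the scatter) and a 5.0-fold lower number from compound 2 to compound 4 (0.70 log units; beyond the scatter), whereas cyano and pyrrolidin-1-yl had stood level here. Going by these compounds alone, compound 4 is thus the one compound of the four whose steps to all the others are printed as beyond the scatter, and it shows that a change at this place alone can lower the concentration that is tolerated. Compound 1 stands at a limit and not at a number, so the exchange of its 1H-indol-5-yl group gives only an at least 5.0-fold lower number from compound 1 to compound 4 (0.69 log units; beyond the scatter), with the true size open: the limit of >= 20 ug/mL in this assay, at which 1 of the 4 values shown sits.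

On these data alone, whether a plain phenylsulfanyl group without the hydroxyl, or a 4-hydroxyphenyl ring joined directly to the carbon, would give the same lower number stays open, so the step cannot be assigned to the sulfur, the ring or the hydroxyl separately. Also open, as far as these compounds go, is where a carboxylic acid or a primary amine at this carbon would stand in this assay.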